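Swapping a Bromophenyl for Butyl on the Triazole

The compounds below may be only part of what the source reports. "The series", "measured", "known", "first", "only" and "open" are said of these compounds alone.

Among the compounds with values here, compound 1 `O=C1O[C@H]([C@@H](O)Cn2cc(-c3ccc(Br)cc3)nn2)C(OCc2ccccc2)=C1OCc1ccccc1` is the only compound here with a numerical result: in a functional assay on HCT-116 cells (Homo sapiens) for antiproliferative activity, read by MTT assay, with a stated time of 72 h (a lower number here means a stronger inhibitor, a higher number a weaker inhibitor), compound 1 gives 9420 nM. Compound 2 `O=C1O/C(=C\Cn2cc(-c3cc(F)cc(F)c3)nn2)C(OCc2ccccc2)=C1OCc1ccccc1`, built on a different variant of the shared core, reaches only a limit of the assay, > 100000 nM, so no number can be set against it. Compound 3 `CCCCc1cn(C[C@H](O)[C@H]2OC(=O)C(OCc3ccccc3)=C2OCc2ccccc2)nn1` differs from compound 1 in one place: butyl in place of 4-bromophenyl on an aromatic carbon. Within the data shown here, no measured pair shows this kind of swap, so the size of the step is uncertain; a modest loss of potency, perhaps not beyond the scatter, is the expectation. One of the two values shown already sits at the limit of > 100000 nM in this assay, at which 1 of the 2 values shown sits, and compound 3 could end there too. Compound 3 is therefore expected to give about 20000 nM, within 6000 nM to 70000 nM. The expected step is a 2.1-fold higher number from compound 1 to compound 3 (0.33 log units; beyond the scatter).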

Compound 3, half-maximal inhibitory concentration: 10400 nM
For compound 3 the middle estimate is 1.9-fold (0.28 log units) above the measured one; measured number inside the range.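

In this assay, the step is a 1.1-fold higher number from compound 1 to compound 3 (0.04 log units; within the scatter), so this swap leaves the result unchanged within the scatter. For this pair, then, the aromatic carbon of the five-membered aromatic ring with 3 nitrogen holds butyl, a chain with no ring and no bromine, with the same result as 4-bromophenyl, so neither that six-membered aromatic ring nor its bromine is needed to keep this level of activity. Compound 2 remains the only one at a limit of the assay rather than a number: the limit of > 100000 nM in this assay, at which 1 of the 3 values shown sits.

A single pair cannot show how far this tolerance extends, for instance to a hexyl chain, a primary amine or a carboxylic acid at the same carbon. Within the data shown here, compound 2 differs from the others in more than one place, so no step to it can be read.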